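The source may report more compounds than this note shows. Statements on the series, on what has been measured and on what is new or still open speak of the compounds shown alone.

Compound 3 `Cc1ccc(N(C(=O)c2cc(F)ccc2F)C(=S)OCCN2C(=O)c3ccccc3C2=O)cc1` stands alongside compound 1 `O=C1c2ccccc2C(=O)N1CCOC(=S)N(C(=O)c1cc(F)ccc1F)c1ccc(Cl)cc1` and compound 2 `O=C1c2ccccc2C(=O)N1CCOC(=S)N(C(=O)c1cc([N+](=O)[O-])ccc1Cl)c1ccc(Cl)cc1` in an ADME assay on MT4 cells (Homo sapiens) for cytotoxicity, read by MTT assay; a lower number here means that less compound is tolerated, a higher number that more compound is tolerated. Compound 1 gives 54000 nM, compound 2 gives 45000 nM, and compound 3 gives 62000 nM, the highest of the three numbers shown, though its distance to each of the other two lies within the scatter. Compound 4 `Cc1ccc(N(C(=O)c2ccc(Br)c(C)c2)C(=S)OCCN2C(=O)c3ccccc3C2=O)cc1` differs from compound 3 by 4-bromo-3-methylphenyl in place of 2,5-difluorophenyl on a carbonyl carbon. The step most in point is a 1.2-fold lower number from compound 1 to compound 2 (0.08 log units; within the scatter), which swapped the ring on the carbonyl carbon and stayed within the scatter; a 1.1-fold higher number from compound 1 to compound 3 (0.06 log units; within the scatter) concerns the other ring and also stayed within the scatter. A change at the same carbonyl position is therefore expected to give a 1.0-fold lower number from compound 3 to compound 4 (0.01 log units; within the scatter). Compound 4 is estimated at 60000 nM, with a range from 30000 nM to 120000 nM.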

Compound 4, half-maximal cytotoxic concentration: > 100000 nM
Compound 4: a limit, no number; the forecaster's own chance of this, stated with the estimate: 15%; middle value at least 1.6-fold (0.22 log units) away from the limit.
By their numbers in this assay, from the lowest: compounds 2, 1 and 3 (each within the scatter of the next). At a limit, above all of these: compound 4.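

In this assay compound 4 gives > 100000 nM, which is a limit of the assay and not a number. The step reads an at least 1.6-fold higher number from compound 3 to compound 4 (0.20 log units; that floor lies within the scatter), so the true size of this change on the carbonyl carbon cannot be told, and its floor does not separate the two compounds. Among the changes shown, only 4-bromo-3-methylphenyl in place of 2,5-difluorophenyl reaches the limit: the limit of > 100000 nM in this assay, at which 1 of the 4 values shown sits.

The compounds shown leave open whether the bromo or the methyl of the entering group matters more. From the compounds shown here alone, what an amine or a carboxylic acid on this ring would give also stays open.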